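A few compounds are considered here, and "the series" means these few. Any claim that something is new, unique, unknown or untested is made for them only; others in the source may bear on it.

For the measured compounds named here, compound 2 `CCOc1cncc(N2CC[C@H]3CN[C@H]3C2)c1` holds the lowest of the two numbers so far: in a functional assay on HEK293 cells for agonist activity at Neuronal acetylcholine receptor; alpha3/beta4 (Homo sapiens), read by FLIPR (a lower number here means that less compound is needed, a higher number that more compound is needed for the effect), compound 2 gives 124 nM, while compound 1 `c1cncc(N2CC[C@@H]3CN[C@@H]3C2)c1` gives 260 nM in this assay, a gap beyond the scatter. Compound 3 `CCOc1cncc(N2CC[C@@H]3CN[C@@H]3C2)c1` has not been measured in this assay. Compound 3 differs from compound 2 in this way: the two compounds have the same atoms and bonds and differ only in configuration as drawn: 2 of 2 stereo elements differ (all stereocentres are inverted: mirror images); a stereocentre at a saturated ring carbon is drawn S in compound 2 and R in compound 3; a stereocentre at a saturated ring carbon is drawn R in compound 2 and S in compound 3. Going by the values given here, no pair with the same kind of change has been measured, so the step from compound 2 to compound 3 could go either way; compound 3 is expected to give 320 nM with a range from 60 nM to 2000 nM, meaning an expected step of a 2.6-fold higher number from compound 2 to compound 3 (0.41 log units; beyond the scatter).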

Compound 3, half-maximal effective concentration: 2800 nM
Beside the measured number, compound 3's estimate is 8.8-fold (0.94 log units) below it, outside the stated range (above it).
By their numbers in this assay, from the lowest: compound 2; then compound 1; then compound 3.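

In this assay, configuration alone carries a large effect, with a 23-fold higher number from compound 2 to compound 3 (1.35 log units; beyond the scatter). That step can be attributed to configuration, because nothing else separates the two: the fact that compounds 2 and 3 differ only in the configuration as drawn. With the configuration held as drawn, ethoxy in place of hydrogen on an aromatic carbon also moves the number the wrong way, with an 11-fold higher number from compound 1 to compound 3 (1.03 log units; beyond the scatter).

As far as these compounds go, whether ethoxy would lower or raise the number in the configuration of compound 2 stays open. So does how a shorter methoxy, a longer propoxy chain or an amine would behave at the same place.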